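The source may report more compounds than this note shows. Statements on the series, on what has been measured and on what is new or still open speak of the compounds shown alone.

Within the data shown here, in an ADME assay on HaCaT cells (Homo sapiens) for inhibition, read by sulforhodamine B assay, with a stated time of 48 h (on this read-out lower numbers stand for stronger inhibition of growth and higher numbers for weaker inhibition of growth), compound 2 `CC(C)(C)NCc1c(C(=O)O)nn(-c2ccccc2)c1-c1ccc(Br)cc1` gives 366000 nM, the only exact number among the compounds tested so far. Compound 3 `CC(C)(C)NCc1c(C(=O)O)nn(-c2ccccc2)c1-c1ccc([N+](=O)[O-])cc1` gives > 634000 nM, which is a limit of the assay and not a number. Compound 1 `CCOC(=O)c1nn(-c2ccc(Cl)cc2)c(-c2ccc(Br)cc2)c1CNC(C)(C)C` gives > 511000 nM; > 476000 nM (2 entries), and these entries are limits too.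

Compound 4 `CC(C)(C)NCc1c(C(=O)O)nn(-c2ccc(Cl)cc2)c1-c1ccc(Br)cc1` has not yet been measured. It differs from compound 2 in one place, where phenyl becomes 4-chlorophenyl: chloro in place of hydrogen on an aromatic carbon. In words, this is chloro in place of hydrogen on an aromatic carbon. Among the measured compounds shown here, no measured step makes this same change, so the evidence is indirect.

For the measured compounds named here, the only measured step swaps a different group, nitro in place of bromo on an aromatic carbon. That step, an at least 1.7-fold higher number from compound 2 to compound 3 (0.23 log units; that floor lies within the scatter), is a floor and not an exact size, and it stays within the scatter. The limits for compound 1 supply no step size at all. On this thin basis, no step beyond the scatter is expected in this assay, and no direction can be favoured. A result reported only as a limit would be quite possible.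

The expected change is a 1.0-fold lower number from compound 2 to compound 4 (0.02 log units; within the scatter). For compound 4 the estimated value is 350000 nM, with an expected range from 180000 nM to 600000 nM.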

Compound 4, concentration for 50% growth inhibition: > 542000 nM
Compound 4 was reported as a limit; the forecaster's own chance of this, stated with the estimate: 45%; at least 1.5-fold (0.18 log units) between middle value and limit.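

In this assay, turning phenyl into 4-chlorophenyl, with chloro in place of hydrogen on an aromatic carbon, gives an at least 1.4-fold higher number from compound 2 to compound 4 (0.17 log units; that floor lies within the scatter). Among these compounds, this is the first reading at this position, as the earlier step swapped a group on the other aromatic ring. Compound 4 gives > 542000 nM, which is a limit of the assay and not a number, so the size of this step is known only as a floor. Compound 1 carries the same 4-chlorophenyl with an ethyl ester in place of the carboxylic acid, but its step to compound 4 cannot be read, as both compounds are reported only as limits: the several entries of compound 1 in this assay, > 511000 nM; > 476000 nM (2 entries)

The compounds shown leave open how far compound 4 truly lies from compound 2, and whether any other group at this position, such as methoxy or an amine, would give an exact number. Going by these compounds, it is also open whether an amide in place of the carboxylic acid would bring the read-out to an exact number on the 4-chlorophenyl compounds.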